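The source may report more compounds than this note shows. Statements on the series, on what has been measured and on what is new or still open speak of the compounds shown alone.

Compound 3 `CC(C)C(=O)N1CCC[C@H]1C(=O)N1CCC(NS(=O)(=O)c2cc(S(=O)(=O)c3ccccc3)ccc2C(F)(F)F)CC1` stands lowest of the three compounds measured in an assay on isolated protein for binding affinity to secreted frizzled-related protein 1 (Homo sapiens), read by fluorescence (a lower number here means a stronger inhibitor, a higher number a weaker inhibitor), where compound 3 gives 40 nM. Compound 1 `CN(C)CC(=O)N1CCC(NS(=O)(=O)c2cc(S(=O)(=O)c3ccccc3)ccc2C(F)(F)F)CC1` gives 300 nM, and compound 2 `CC(C)(C)OC(=O)N1CCC[C@@H]1C(=O)N1CCC(NS(=O)(=O)c2cc(S(=O)(=O)c3ccccc3)ccc2C(F)(F)F)CC1` gives 120 nM. The steps run a 7.5-fold lower number from compound 1 to compound 3 (0.88 log units; beyond the scatter) and a 3.0-fold lower number from compound 2 to compound 3 (0.48 log units; beyond the scatter); both exchange the group on the carbonyl carbon, and both end at the 1-(isopropylcarbonyl)pyrrolidin-2-yl group of compound 3. Compound 4 `CC(C)(C)C(=O)N1CCC[C@H]1C(=O)N1CCC(NS(=O)(=O)c2cc(S(=O)(=O)c3ccccc3)ccc2C(F)(F)F)CC1` differs from compound 3 by methyl in place of hydrogen on a saturated chain carbon bound to a carbonyl carbon and two saturated chain carbons. For the measured compounds named here, no measured step adds a single methyl in this way, so the only guide is that exchanging the whole group on that carbonyl carbon moved the number modestly. The expected step is a 1.3-fold higher number from compound 3 to compound 4 (0.10 log units; within the scatter), within the usual scatter or a little beyond. Compound 4 is therefore estimated at 50 nM, between 20 nM and 130 nM.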

Compound 4, half-maximal inhibitory concentration: 40 nM
Compound 4: middle estimate off by 1.3-fold (0.10 log units), on the high side; the measured number falls inside the stated range.
By their numbers in this assay, from the lowest: compounds 3 and 4 (each within the scatter of the next); then compound 2; then compound 1.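

Adding the methyl that turns isopropyl into tert-butyl gives no change at the digits printed from compound 3 to compound 4 (within the scatter) in this assay, so this position accepts the extra methyl with no measurable loss. The tert-butyl amide also holds the full advantage seen with the isopropyl amide, with a 3.0-fold lower number from compound 2 to compound 4 (0.48 log units; beyond the scatter) and a 7.5-fold lower number from compound 1 to compound 4 (0.88 log units; beyond the scatter). No available evidence explains why the number stays level here. Still open, going by these compounds, is what a longer chain, such as n-butyl, or a phenyl ring in place of tert-butyl would do to the number.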